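The compounds below may be only part of what the source reports. "The series", "measured", "known", "first", "only" and "open" are said of these compounds alone.

Measured so far:
- compound 1, `CN(C)CCn1c(=O)sc2cc(S(=O)(=O)N(C)c3ccccc3)ccc21`: 91000 nM
- compound 2, `CN(c1ccccc1)S(=O)(=O)c1ccc2c(c1)sc(=O)n2CCN1CCCCC1`: 50000 nM

Within the data shown here, in an ADME assay on SH-SY5Y cells (Homo sapiens) for inhibition, read by MTT assay, with a stated time of 72 h (on this read-out higher numbers stand for weaker inhibition and lower numbers for stronger inhibition), compound 2 carries the lower of the two numbers, yet the sole measured step, a 1.8-fold lower number from compound 1 to compound 2 (0.26 log units; within the scatter), lies within the scatter, so the two compounds cannot be told apart on these data. That step concerns the amine at the end of the chain and says nothing about the sulfonamide nitrogen.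

Compound 3, `O=c1sc2cc(S(=O)(=O)Nc3ccccc3)ccc2n1CCN1CCCCC1`, differs from compound 2 by hydrogen in place of methyl on a sulfonamide nitrogen. Among the measured compounds shown here, no measured pair touches this position, so there is no step to lean on. With only the within-scatter step between compound 1 and compound 2 available, the expectation for compound 3 in this assay is a change no larger than the scatter: no change at the digits printed from compound 2 to compound 3 (within the scatter). The estimate for compound 3 is therefore 50000 nM, with a range from 20000 nM to 125000 nM.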

Compound 3, half-maximal inhibitory concentration: 17400 nM
For compound 3 the middle estimate is 2.9-fold (0.46 log units) above the measured one; measured number below the stated range.
By their numbers in this assay, from the lowest: compound 3; then compounds 2 and 1 (each within the scatter of the next).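

Hydrogen in place of methyl on a sulfonamide nitrogen gives a 2.9-fold lower number from compound 2 to compound 3 (0.46 log units; beyond the scatter) in this assay and so provides the first step in this series that lies beyond the scatter, though only a modest one. Among these compounds, the earlier compounds showed only a change of amine at the end of the chain, which stayed within the scatter, so this result is the first sign that the number responds to a structural change, here at the sulfonamide nitrogen and with the loss of a single carbon. No evidence is available to explain this step.

The compounds shown leave open whether the same change gives a similar step with dimethylamino on the chain, since it is seen here only with piperidin-1-yl. They also leave open how an ethyl or a benzyl group on that sulfonamide nitrogen would compare with methyl and hydrogen.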